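Methoxy to bromo on the outer ring: expected step

This account rests on a few compounds, and the source may have more. Where it says the series, first, only, none or still open, it means among the compounds named here.

Three compounds share one core and differ only in the group carried on the outer aromatic ring. Compound 1 `Cc1ccc(NC(=S)N/N=C2\C(=O)Nc3ccc([N+](=O)[O-])cc32)cc1` carries a methyl group; in a functional assay on the whole organism for inhibition, with Lemna aequinoctialis as the target, tested at 10 ug/mL (on this read-out lower numbers stand for less inhibition of growth and higher numbers for more inhibition of growth at the one concentration tested), compound 1 gives 15%. Compound 2 `COc1ccc(NC(=S)N/N=C2\C(=O)Nc3ccc([N+](=O)[O-])cc32)cc1` carries a methoxy group instead; in this assay compound 2 gives 10%. The step of a number 5 percentage points lower from compound 1 to compound 2 (within the scatter) is within the scatter. Compound 3 `O=C1Nc2ccc([N+](=O)[O-])cc2/C1=N/NC(=S)Nc1ccccc1C(F)(F)F` carries a trifluoromethyl group; in this assay compound 3 gives 10%. On these numbers compound 2 stands level with compound 3, and the number of compound 1 differs from it only within the scatter, so all three read alike.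

Compound 4 `O=C1Nc2ccc([N+](=O)[O-])cc2/C1=N/NC(=S)Nc1ccc(Br)cc1` is the next variation: bromo in place of methoxy on an aromatic carbon, a methoxy group gives way to a bromo group on an aromatic carbon of a six-membered aromatic ring of carbon only, para to a large group. For the measured compounds named here, no measured step involves a bromo group. Going by the values given here, the only step that bears on this change is a number 5 percentage points lower from compound 1 to compound 2 (within the scatter), which stayed within the scatter, and compound 2 and compound 3 show the same number. Changing the group on this ring has so far not moved this assay beyond the scatter, so no step beyond it is expected here either. Compound 4 is expected to give 12% in this assay, between 2% and 25%. That expected value means the step of a number 2 percentage points higher from compound 2 to compound 4 (within the scatter).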

Compound 4, percent growth inhibition at one concentration: 10%
The estimate for compound 4 lay 2 percentage points above the measured number; the measured number falls inside the stated range.
By their numbers in this assay, from the lowest: compounds 2, 3, 4 and 1 (each within the scatter of the next).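

In this assay, bromo in place of methoxy on an aromatic carbon, para to a large group, gives no change at the digits printed from compound 2 to compound 4 (within the scatter), and bromo in place of methyl at that same place gives a number 5 percentage points lower from compound 1 to compound 4 (within the scatter). Methyl, methoxy and bromo therefore read alike here, and the swap from methoxy to bromo, which removes a hydrogen-bond acceptor and replaces two heavy atoms with a single bromine atom, leaves the read-out within the scatter. The data shown offer no explanation for why these groups read alike, so this remains an observation about three groups and not a rule about the position.

From the compounds shown here alone, it remains open whether a group of a different kind at this place, such as an amine, a carboxylic acid or a longer chain, would move the number beyond the scatter. These results also come from a single test concentration, so they leave open whether compounds that read alike there would still read alike at other concentrations.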